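Hydrazone variation on the shared core: chlorophenyl to phenyl ketimine

The source may hold more compounds than are shown below. What is called first, only, known or untested is meant among the compounds shown, and "the series" means these compounds.

Two hydrazones of the shared core have numbers in an assay on isolated protein for inhibition of Amine oxidase [flavin-containing] B (Homo sapiens), read by spectrophotometry; on this read-out higher numbers stand for weaker inhibition and lower numbers for stronger inhibition. Compound 1 `COc1ccc(/C(C)=N/Nc2nc3ccccc3nc2Cc2ccccc2)cc1` gives 280000 nM in this assay. Compound 2 `Clc1ccc(/C=N/Nc2nc3ccccc3nc2Cc2ccccc2)cc1` gives 84000 nM in this assay, the lowest of the two numbers, with compound 1 a step away that is beyond the scatter. Within the data shown here, no step between measured compounds that differ in one place is known here.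

Compound 3 `C/C(=N\Nc1nc2ccccc2nc1Cc1ccccc1)c1ccccc1` is the next member. It differs from compound 2 by a group of 9 heavy atoms (8 carbon, 1 nitrogen; one six-membered aromatic ring of carbon only) in place of a group of 9 heavy atoms (7 carbon, 1 nitrogen, 1 chlorine; one six-membered aromatic ring of carbon only), on a nitrogen on an aromatic ring. Because compound 1, which also carries a methyl on the double bond outside the aromatic rings, gives 280000 nM in this assay, the expectation for the step from compound 2 to compound 3 is a rise of a 1.9-fold higher number from compound 2 to compound 3 (0.28 log units; within the scatter), in the direction of weaker inhibition and likely beyond the scatter, although this rests on two numbers only. Compound 3 is therefore estimated at 160000 nM in this assay, within a range from 55000 nM to 450000 nM.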

Compound 3, half-maximal inhibitory concentration: 980000 nM
The estimate for compound 3 lay 6.1-fold (0.79 log units) below the measured number; measured number outside the range, above it.
By their numbers in this assay, from the lowest: compound 2; then compound 1; then compound 3.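

In this assay, the group on a nitrogen on an aromatic ring has a large influence, with the exchange of the chlorine-bearing group for the group of 8 carbon and 1 nitrogen giving a 12-fold higher number from compound 2 to compound 3 (1.07 log units; beyond the scatter). Among the two compounds that carry a methyl on the double bond, hydrogen in place of methoxy on an aromatic carbon gives a modest step, a 3.5-fold higher number from compound 1 to compound 3 (0.54 log units; beyond the scatter), so this single ring change moves the number beyond the scatter and compound 3 is the weakest of the three. Nothing here accounts for either step.

The step from compound 2 combines loss of chlorine with gain of the methyl, and the compounds shown do not separate the two contributions. Also open, from the compounds shown here alone, is how an amine or a carboxylic acid on the aromatic carbon, or a longer chain in place of the methyl, would read.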